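The compounds below may be only part of what the source reports. "The series", "measured", "known", "first", "only" and "open" are said of these compounds alone.

Measured so far in a functional assay on A549 cells (Homo sapiens) for cytotoxicity, read by MTT assay, with a stated time of 24 h; a higher number here means a weaker inhibitor, a lower number a stronger inhibitor:
Compound 1 `Cc1ncc([N+](=O)[O-])n1CCOc1ccc(F)cc1` gives 129 ug/mL.
Compound 2 `Cc1cc(OCCn2c([N+](=O)[O-])cnc2C)ccc1F` gives 226 ug/mL.

Compound 2 stands apart from compound 1 only by a 1.8-fold higher number from compound 1 to compound 2 (0.24 log units; within the scatter), a gap within the scatter, so the two cannot be told apart. Compound 3 `Cc1ncc([N+](=O)[O-])n1CCOc1ccc(F)c(Cl)c1` differs from compound 2 by chloro in place of methyl on an aromatic carbon. Among the compounds with values here, no measured step swaps one small group for another at that place; the one step known, from compound 1 to compound 2, stayed within the scatter. A step of a 1.1-fold lower number from compound 2 to compound 3 (0.05 log units; within the scatter) in this assay is therefore expected, nothing beyond the scatter. Compound 3 is expected to give about 200 ug/mL, likely between 100 ug/mL and 400 ug/mL.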

Compound 3, half-maximal inhibitory concentration: 122 ug/mL
Compound 3: middle estimate off by 1.6-fold (0.21 log units), on the high side, within the range that was stated.
By their numbers in this assay, from the lowest: compounds 3, 1 and 2 (each within the scatter of the next).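

Chloro in place of methyl gives a 1.9-fold lower number from compound 2 to compound 3 (0.27 log units; within the scatter) and chloro in place of hydrogen gives a 1.1-fold lower number from compound 1 to compound 3 (0.02 log units; within the scatter) in this assay at this position, ortho to a fluoro group. Hydrogen, methyl and chloro therefore cannot be told apart here, whereas the earlier compounds offered only hydrogen and methyl. No measurement at hand accounts for this result. On these data alone, whether an amine or a carboxylic acid at this position would also stay within the scatter remains open, as does the effect of a longer chain there.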